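The source may hold more compounds than are shown below. What is called first, only, known or untested is meant among the compounds shown, and "the series" means these compounds.

Measured so far:
- compound 1, `COc1ccc(C(=O)C2Sc3nnc(-c4cc(OC)c(OC)c(OC)c4)n3NC2c2ccco2)cc1`: > 100000 nM
- compound 2, `COc1cc(-c2nnc3n2NC(c2ccco2)C(C(=O)c2ccc(F)c(F)c2)S3)cc(OC)c1OC`: 93700 nM
- compound 3, `COc1cc(-c2nnc3n2NC(c2ccco2)C(C(=O)c2ccc(C(F)(F)F)cc2)S3)cc(OC)c1OC`: 37200 nM

The value recorded for compound 1 in a functional assay on A549 cells (Homo sapiens) for cytotoxicity, read by MTT assay, with a stated time of 48 h (on this read-out lower numbers stand for stronger inhibition and higher numbers for weaker inhibition), is a limit of the assay and not a number (the limit of > 100000 nM in this assay, at which 1 of the 3 values shown sits). Among the two numbers in this assay compound 3 stands lowest, with compound 2 nearest: a 2.5-fold lower number from compound 2 to compound 3 (0.40 log units; beyond the scatter). From compound 1 the step reads an at least 2.6-fold lower number from compound 1 to compound 3 (0.42 log units; beyond the scatter), while the step of an at least 1.0-fold lower number from compound 1 to compound 2 (0.02 log units; that floor lies within the scatter) is only a floor.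

Compound 4, `COc1cc(-c2nnc3n2NC(c2ccco2)C(C(=O)c2ccco2)S3)cc(OC)c1OC`, is unmeasured. Its change from compound 3 is furan-2-yl in place of 4-(trifluoromethyl)phenyl on a carbonyl carbon. Within the data shown here, no measured step covers this exchange; the three known steps all swap one substituted phenyl on the carbonyl carbon for another, and they move the number in this assay by modest amounts at most. Furan-2-yl is a smaller ring with one hetero atom, outside the range of groups tried so far, so the direction is open. The expectation for compound 4 in this assay is a weakening relative to compound 3, a 1.9-fold higher number from compound 3 to compound 4 (0.27 log units; within the scatter), of about the size seen between compound 2 and compound 3, with wide uncertainty and a real chance that only a limit is returned. Compound 4 is estimated at 70000 nM, within 25000 nM to 200000 nM.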

Compound 4, half-maximal inhibitory concentration: 68700 nM
Beside the measured number, compound 4's estimate is 1.0-fold (0.01 log units) above it; low and high end bracket the measured number.
By their numbers in this assay, from the lowest: compounds 3, 4 and 2 (each within the scatter of the next, the first and the last beyond it). At a limit, above all of these: compound 1.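

Furan-2-yl is the first group on this carbonyl carbon that is not a substituted phenyl, and in this assay the exchange stays within the scatter in both readable comparisons: a 1.8-fold higher number from compound 3 to compound 4 (0.27 log units; within the scatter), and a 1.4-fold lower number from compound 2 to compound 4 (0.13 log units; within the scatter). A substituted phenyl is therefore not needed at this position to give a number in this range, and compound 4 cannot be placed in order relative to compound 2 or compound 3, even though a 2.5-fold lower number from compound 2 to compound 3 (0.40 log units; beyond the scatter) separates those two from each other. The third step, an at least 1.4-fold lower number from compound 1 to compound 4 (0.16 log units; that floor lies within the scatter), is only a floor and cannot be read as a change, and the value of compound 1 is a limit of the assay and not a number: the limit of > 100000 nM in this assay, at which 1 of the 4 values shown sits.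

Open, going by these compounds, is whether a saturated ring such as cyclohexyl, a simple alkyl chain on the carbonyl carbon, or an amine or a carboxylic acid carried on the ring there would keep the number in this range or move it. The rest of the shared core is the same in all four compounds, so these compounds say nothing about changes made elsewhere on it.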